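Chromene chalcones: a nitro analogue of compound 3

A few compounds are considered here, and "the series" means these few. Any claim that something is new, unique, unknown or untested is made for them only; others in the source may bear on it.

Measured so far:
- Compound 1 `COc1ccc(C(=O)/C=C/c2cccc(F)c2)c2c1C=CC(C)(C)O2`: in a functional assay on SW-620 cells (Homo sapiens) for antiproliferative activity, read by MTT assay, with a stated time of 24 h (on this read-out lower numbers stand for stronger inhibition and higher numbers for weaker inhibition), compound 1 gives > 10000 nM, which is a limit of the assay.
- Compound 2 `CCN(CC)c1ccc(/C=C/C(=O)c2ccc(OC)c3c2OC(C)(C)C=C3)cc1`: compound 2 gives 670 nM.
- Compound 3 `COc1ccc(C(=O)/C=C/c2ccc(-n3ccnc3)cc2)c2c1C=CC(C)(C)O2`: compound 3 gives > 10000 nM, again a limit, not a number.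

Compound 3 thus sits at the limit of > 10000 nM in this assay, at which 2 of the 3 values shown sit, alongside compound 1; only compound 2 yields a number. Compound 4 `COc1ccc(C(=O)/C=C/c2ccc([N+](=O)[O-])cc2)c2c1C=CC(C)(C)O2` differs from compound 3 by nitro in place of 1H-imidazol-1-yl on an aromatic carbon. Among the compounds with values here, the one measured step at this position, an at least 14-fold higher number from compound 2 to compound 3 (1.17 log units; beyond the scatter), concerns a different substituent pair and carries over only loosely. Nothing among the numbers distinguishes nitro from imidazolyl here, so compound 4 is expected to remain at the limit, with a number no higher from compound 3 to compound 4 (the limit leaves the size open) as the estimated step. The estimate for compound 4 is 10000 nM, range 3000 nM to 30000 nM.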

Compound 4, half-maximal inhibitory concentration: 3520 nM
Compound 4: middle estimate off by 2.8-fold (0.45 log units), on the high side; the measured number falls inside the stated range.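

In this assay, compound 4 shows that nitro on this aromatic carbon, without diethylamino, is sufficient to leave the limit: the limit of > 10000 nM in this assay, at which 2 of the 4 values shown sit. Replacing 1H-imidazol-1-yl gives an at least 2.8-fold lower number from compound 3 to compound 4 (0.45 log units; beyond the scatter), and replacing the 3-fluorophenyl group with 4-nitrophenyl gives an at least 2.8-fold lower number from compound 1 to compound 4 (0.45 log units; beyond the scatter). Nitro still falls short of diethylamino, with a 5.3-fold higher number from compound 2 to compound 4 (0.72 log units; beyond the scatter).

Only nitro and diethylamino give numbers here, so no trend across substituents can be drawn. As far as these compounds go, it remains open whether a primary amine or dimethylamino at this carbon would match diethylamino, and how a carboxylic acid would behave.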